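The source may report more compounds than this note shows. Statements on the series, on what has been measured and on what is new or still open speak of the compounds shown alone.

Compound 1 `O=C1O/C(=C\Cn2cc(-c3cc(F)cc(F)c3)nn2)C(OCc2ccccc2)=C1OCc1ccccc1`: > 100000 nM
Compound 2 `COc1ccccc1-c1cn(C[C@H](O)[C@H]2OC(=O)C(OCc3ccccc3)=C2OCc2ccccc2)nn1`: > 100000 nM

Of the compounds shown here, two have so far been measured in a functional assay on MCF7 cells (Homo sapiens) for antiproliferative activity, read by MTT assay, with a stated time of 72 h; on this read-out lower numbers stand for stronger inhibition and higher numbers for weaker inhibition. For compound 1 the value recorded, > 100000 nM, is a limit of the assay rather than a number. Compound 2 likewise shows only a limit, > 100000 nM, in this assay. Both recorded values sit at the same point, (the limit of > 100000 nM in this assay, at which 2 of the 2 values shown sit), so compound 2 stands where every measured member of the set stands, with no numerical potency recorded. Compound 3 `O=C1O[C@H]([C@@H](O)Cn2cc(CCO)nn2)C(OCc2ccccc2)=C1OCc1ccccc1` has not yet been measured. It differs from compound 2 in one place: 2-hydroxyethyl in place of 2-methoxyphenyl on an aromatic carbon. Among the measured compounds shown here, with no measured step in this assay to draw on, no shift beyond the scatter is expected in this assay, and compound 3 is expected to remain at the limit as well. The expected step of a number no higher from compound 2 to compound 3 (the limit leaves the size open) is therefore essentially none. Compound 3 is estimated at 100000 nM, within a range from 30000 nM to 300000 nM.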

Compound 3, half-maximal inhibitory concentration: 63400 nM
Estimate against measurement, compound 3: 1.6-fold (0.20 log units) above, and the stated range covers the measured number.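

With 2-hydroxyethyl in place of 2-methoxyphenyl on the aromatic carbon of the five-membered aromatic ring, this assay shows an at least 1.5-fold lower number from compound 2 to compound 3 (0.19 log units; that floor lies within the scatter). From the compounds shown here alone, compound 2 holds only a limit, so the true size of this step stays open, and the printed floor alone does not show a change beyond the scatter. Among the compounds shown here, compound 3 is the only one of the three compounds to give a number rather than a limit: the limit of > 100000 nM in this assay, at which 2 of the 3 values shown sit.

The compounds shown do not separate the loss of the aromatic ring from the arrival of the hydroxyl group. Going by these compounds, how a plain ethyl group, a 2-methoxyethyl chain, a longer chain such as 3-hydroxypropyl or an amine would read at this position remains open.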